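The compounds below may be only part of what the source reports. "The series", "measured", "known", "first", "only" and "open" are said of these compounds alone.

Of the compounds shown here, two have been measured in a functional assay on CHO cells for agonist activity at Free fatty acid receptor 1 (Homo sapiens), read by reporter gene assay; on this read-out lower numbers stand for smaller maximal responses and higher numbers for larger maximal responses. Compound 1, with the structure `O=C(O)C1CC1c1ccc(NCc2ccc(-c3ccccc3)cc2)cc1`, gives 80% in this assay. Compound 2, with the structure `O=C(O)CCc1ccc(NCc2ccc(C(F)(F)F)cc2)cc1`, gives 133% in this assay. Compound 2 thus stands at the highest of the two numbers, and compound 1 lies well lower, a gap beyond the usual scatter of repeated measurements. The two compounds differ in more than one place; the gap cannot be tied to any single change.

Compound 3, with the structure `N#Cc1ccc(CNc2ccc(CCC(=O)O)cc2)cc1`, has not yet been measured. It differs from compound 2 as follows: cyano in place of trifluoromethyl on an aromatic carbon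

For the measured compounds named here, no pair of measured compounds that differ in one place is available, and the effect of exchanging these two groups can only be expected, not read off. Compound 2 already reaches 133% in this assay. A modest drop, or no step beyond the scatter, is expected for compound 3; the step expected in this assay is a number 18 percentage points lower from compound 2 to compound 3 (beyond the scatter). The estimate for compound 3 in this assay is 115%, with a likely range from 80% to 145%.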

Compound 3, largest response reached (reported as percent of maximum), in percent of the reference or control that the assay uses: 49%
The estimate for compound 3 lay 66 percentage points above the measured number; the whole stated range lies above it.
By their numbers in this assay, from the lowest: compound 3; then compound 1; then compound 2.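

For the compounds shown here, for the first time, a single change in one place can be read directly: in this assay, cyano in place of trifluoromethyl on an aromatic carbon gives a number 84 percentage points lower from compound 2 to compound 3 (beyond the scatter). The maximal response therefore depends strongly on which of these two groups sits at this position, para to a large group, even though the rest of the structure stays the same. The exchange replaces a group of 4 heavy atoms and 0 hydrogen-bond acceptors with one of 2 heavy atoms and 1 hydrogen-bond acceptor, but no measurement available here connects the fall in response to either difference.

Going by these compounds alone, with only two groups compared at this position, it remains open whether the response follows the number of heavy atoms, the hydrogen-bond acceptor or something else about the groups. On these data alone, a chlorine atom or a methoxy group at the same place would add points to that comparison, and the effect of this same exchange on the core of compound 1 also remains unknown.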